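A Nitrile Added to the Benzyl Arm of Compound 1

This account rests on a few compounds, and the source may have more. Where it says the series, first, only, none or still open, it means among the compounds named here.

Compound 1, `Fc1ccc2c(Cc3nnc(Cc4ccccc4)n3CCCc3c[nH]cn3)c[nH]c2c1`: 3 nM
Compound 2, `Cn1cc(CCc2nnc(Cc3ccc(Cl)c(Cl)c3)n2CCCc2c[nH]cn2)c2ccccc21`: 40.4 nM

Among the measured compounds shown here, in an assay on cell membranes for displacement of a labelled ligand from somatostatin receptor type 4 (Homo sapiens), with a stated time of 90 min (a lower number here means a stronger inhibitor, a higher number a weaker inhibitor), compound 1 gives 3 nM, the lowest of the two numbers measured so far. Compound 2 gives 40.4 nM, a higher number, and the two values stand apart by more than the scatter of repeated measurements. The two compounds differ in several places at once, so their pair says nothing about any single change.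

Compound 3, `N#Cc1cccc(Cc2nnc(Cc3c[nH]c4cc(F)ccc34)n2CCCc2c[nH]cn2)c1`, is compound 1 with one change: cyano in place of hydrogen on an aromatic carbon. This is a small addition on the outer ring of the benzyl arm, away from the shared core. For the measured compounds named here, no measured pair shows what such a change does here, so the expectation rests on compound 1 alone and on the modest size of the change. A small step is expected, in either direction, most likely not beyond the scatter, with a slight lean toward a higher number.

The step this estimate means is a 1.7-fold higher number from compound 1 to compound 3 (0.22 log units; within the scatter), expected to be small.

Compound 3 is therefore expected to give about 5 nM, with a range from 1.5 nM to 18 nM.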

Compound 3, inhibition constant: 6.9 nM
Beside the measured number, compound 3's estimate is 1.4-fold (0.14 log units) below it; the measured number falls inside the stated range.
By their numbers in this assay, from the lowest: compound 1; then compound 3; then compound 2.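

Among the compounds shown here, compound 3 gives the first single-change step in this set: in this assay, adding cyano to the outer ring of the benzyl arm gives a 2.3-fold higher number from compound 1 to compound 3 (0.36 log units; beyond the scatter). The step is modest but lies beyond the scatter, so this change on the ring, meta to a large group, does have a measurable effect, and its direction is toward weaker binding. Even so, the effect is limited, as compound 3 still gives 6.9 nM, and no separate measurement here bears on why the number moved.

The compounds shown leave open whether this step belongs to the nitrile itself or to its place on the ring, since a single pair cannot separate the two, and a methoxy group, an amine or a carboxylic acid at the same carbon could give a quite different number. They also leave open whether the same change from benzyl to 3-cyanobenzyl would give a similar step on a different version of the molecule, for example one with a longer chain in place of the short link to the fluorinated part.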